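The compounds below may be only part of what the source reports. "The series", "measured", "known", "first", "only" and "open" are said of these compounds alone.

Two analogues of the shared core have numbers in a functional assay on PC-3 cells (Homo sapiens) for cytotoxicity, read by MTT assay, with a stated time of 72 h; on this read-out higher numbers stand for weaker inhibition and lower numbers for stronger inhibition. Compound 1 `CC1=C(/C=C/C(=O)/C=C/c2cccc(C(F)(F)F)c2)C(C)(C)CCC1O` gives 3500 nM in this assay. Compound 2 `CC1=C(/C=C/C(=O)/C=C/c2ccccc2F)C(C)(C)CCC1O` gives 10400 nM in this assay, the highest of the two numbers; compound 1 stands at the lower number, and that gap lies beyond the scatter. Compound 3 `CC1=C(/C=C/C(=O)/C=C/c2cccc(C(F)(F)F)c2F)C(C)(C)CCC1O` carries trifluoromethyl in place of hydrogen on an aromatic carbon, so it holds the trifluoromethyl of compound 1 together with the fluoro group of compound 2. The step from compound 2 to compound 3 in this assay is expected to run downward, toward the number of compound 1, by a 2.1-fold lower number from compound 2 to compound 3 (0.32 log units; beyond the scatter). Compound 3 is then expected to give about 5000 nM in this assay, within a range from 2000 nM to 15000 nM.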

Compound 3, half-maximal inhibitory concentration: 2100 nM
Estimate against measurement, compound 3: 2.4-fold (0.38 log units) above; the measured number falls inside the stated range.
By their numbers in this assay, from the lowest: compounds 3 and 1 (each within the scatter of the next); then compound 2.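

In this assay, trifluoromethyl in place of hydrogen on the aromatic carbon ortho to a fluoro group strengthens inhibition (a 5.0-fold lower number from compound 2 to compound 3 (0.69 log units; beyond the scatter)), so this position accepts the group when the fluoro group is present. Fluoro in place of hydrogen on compound 1 leaves no readable change (a 1.7-fold lower number from compound 1 to compound 3 (0.22 log units; within the scatter)), so with trifluoromethyl present, that fluoro group adds nothing beyond the scatter. No measurement bears on the reason for either step. Still open, from the compounds shown here alone, is whether a nitrile or a methoxy group at this position would match trifluoromethyl.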